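Methyl Branching on the Propyl Chain of Compound 2

This account rests on a few compounds, and the source may have more. Where it says the series, first, only, none or still open, it means among the compounds named here.

Compound 1 `CCC(CC)n1c(-c2ccc(OCc3c(-c4c(Cl)cccc4Cl)noc3C(C)C)cc2F)nc2ccc(C(=O)O)cc21`: 69.3 nM
Compound 2 `CCCn1c(-c2ccc(OCc3c(-c4c(Cl)cccc4Cl)noc3C(C)C)cc2)nc2ccc(C(=O)O)cc21`: 96.4 nM

Of the compounds shown here, two have so far been measured in an assay on isolated protein for agonist activity at Bile acid receptor (Homo sapiens), read by TR-FRET; a lower number here means that less compound is needed, a higher number that more compound is needed for the effect. Compound 1 gives 69.3 nM and compound 2 gives 96.4 nM. Compound 2 stands with the higher of the two numbers, but the gap to compound 1 is within the usual scatter, so the two cannot be ordered on this evidence. For the measured compounds named here, compound 1 and compound 2 also differ in more than one place, so no single step between measured compounds is available.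

Compound 3 `CC(C)Cn1c(-c2ccc(OCc3c(-c4c(Cl)cccc4Cl)noc3C(C)C)cc2)nc2ccc(C(=O)O)cc21` is the next compound to be measured. It differs from compound 2 by methyl in place of hydrogen on a saturated chain carbon bound to two saturated chain carbons. Nothing measured here isolates this particular change, so the expectation rests only on the two values in hand, which sit close together. The step from compound 2 to compound 3 is therefore expected to be small, with no clear direction and none beyond the scatter, written as a 1.2-fold lower number from compound 2 to compound 3 (0.08 log units; within the scatter). On that basis compound 3 is estimated at 80 nM, with a range from 30 nM to 220 nM.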

Compound 3, half-maximal effective concentration: 24.7 nM
Estimate against measurement, compound 3: 3.2-fold (0.51 log units) above, outside the stated range (below it).
By their numbers in this assay, from the lowest: compound 3; then compounds 1 and 2 (each within the scatter of the next).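

In this assay, for the compounds shown here, methyl in place of hydrogen on a saturated chain carbon bound to two saturated chain carbons, which turns the propyl chain into an isobutyl chain, gives a 3.9-fold lower number from compound 2 to compound 3 (0.59 log units; beyond the scatter) and provides the first reading of a change in one place. It shows that this chain position is not indifferent to substitution: a single added carbon moves the number beyond the scatter, whereas the two earlier values could not be ordered and their compounds differed in more than one place. No available measurement bears on why this change lowers the number.

The compounds shown leave open whether a larger group at the same carbon, such as an ethyl or a second methyl, would lower the number further, and whether a hydroxyl or an amine there would be accepted at all. They also leave open whether the step from propyl to isobutyl would be of similar size with the fluorine found on the core of compound 1 present.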